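This account rests on a few compounds, and the source may have more. Where it says the series, first, only, none or still open, it means among the compounds named here.

Three compounds have been measured in a functional assay on HEK293 cells for antagonist activity at Voltage-dependent L-type calcium channel subunit alpha-1D (Rattus norvegicus), read by FLIPR; on this read-out higher numbers stand for weaker inhibition and lower numbers for stronger inhibition:
compound 1, `COC(=O)C1=C(C)NC(C)=C(C(=O)OCC2CC2)C1c1cccc([N+](=O)[O-])c1`, gives 21 nM;
compound 2, `COC(=O)C1=C(C)NC(C)=C(C(=O)OCc2cc([N+](=O)[O-])cc([N+](=O)[O-])c2)C1c1cccc([N+](=O)[O-])c1`, gives 40 nM;
compound 3, `COC(=O)C1=C(C)NC(C)=C(C(=O)OCc2ccc(F)c(F)c2)C1c1cccc([N+](=O)[O-])c1`, gives 20 nM.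

Compound 3 holds the lowest of these three numbers, but both of the other compounds lie within the scatter of it: the step of a 1.1-fold lower number from compound 1 to compound 3 (0.02 log units; within the scatter) is barely visible, and the step of a 2.0-fold lower number from compound 2 to compound 3 (0.30 log units; within the scatter) sits at the edge of what repeated measurements would resolve. The three compounds differ from one another only in the group on the saturated chain carbon bound to an oxygen next to a carbonyl group, and across cyclopropyl, 3,5-dinitrophenyl and 3,4-difluorophenyl this assay returns much the same number, the widest gap being a 1.9-fold higher number from compound 1 to compound 2 (0.28 log units; within the scatter).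

Compound 4, `COC(=O)C1=C(C)NC(C)=C(C(=O)OCc2ccc(OC)c(OC)c2)C1c1cccc([N+](=O)[O-])c1`, alters the same place once more: 3,4-dimethoxyphenyl in place of 3,4-difluorophenyl on a saturated chain carbon bound to an oxygen next to a carbonyl group. All three measured steps bear on this change, since each exchanged the group at this position, and none of them moved beyond the scatter. The expectation for compound 4 is therefore no step beyond the scatter, with a 1.3-fold higher number from compound 3 to compound 4 (0.10 log units; within the scatter) as the estimated change. Compound 4 is estimated at 25 nM, with a range from 10 nM to 65 nM.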

Compound 4, half-maximal inhibitory concentration: 117 nM
Beside the measured number, compound 4's estimate is 4.7-fold (0.67 log units) below it; the whole stated range lies below it.
By their numbers in this assay, from the lowest: compounds 3, 1 and 2 (each within the scatter of the next); then compound 4.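

Within the data shown here, the group on the saturated chain carbon bound to an oxygen next to a carbonyl group had seemed to make little difference among compound 1, compound 2 and compound 3, but in this assay this position does respond to the group it carries, with a 5.9-fold higher number from compound 3 to compound 4 (0.77 log units; beyond the scatter) and a 5.6-fold higher number from compound 1 to compound 4 (0.75 log units; beyond the scatter) and also a 2.9-fold higher number from compound 2 to compound 4 (0.47 log units; beyond the scatter) as the first steps beyond the scatter, all of them modest. The exchange of 3,4-difluorophenyl for 3,4-dimethoxyphenyl keeps one six-membered aromatic ring of carbon only, while the group gains heavy atoms and goes from 0 hydrogen-bond acceptors to 2, so an aromatic ring at this position does not by itself fix the number, and compound 2 and compound 3 stay within the scatter of the cyclopropyl compound 1. Nothing shown here accounts for the size of these steps.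

The compounds shown leave open whether both methoxy groups are needed for the step or whether a phenyl carrying a single methoxy group would already give it. They also leave open how this position would respond to an unsubstituted phenyl, a hydroxyphenyl, an amine or a longer chain.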